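This account rests on a few compounds, and the source may have more. Where it says the series, first, only, none or still open, it means among the compounds named here.

Working notes on the series. The shared core of compound 1 `COc1cc(OC)c2c(=O)cc(-c3ccc(OCCCN(C)C)cc3)oc2c1` carries a varied side chain; in a functional assay (Homo sapiens) for antiproliferative activity, read by resazurin assay, with a stated time of 48 h, tested at 20 uM (a lower number here means a weaker effect, a higher number a stronger effect of the compound at the concentration tested), compound 1 gives 86%, the highest of the two numbers reported. Compound 2 `COc1cc(OC)c2c(=O)cc(-c3ccc(OC4CCNCC4)cc3)oc2c1` has "not determined" (no result reported), and compound 3 `COc1cc(OC)c2c(=O)cc(-c3ccc(OCCN)cc3)oc2c1` gives 70%. Going by the values given here, the only measured step at this place, a number 16 percentage points lower from compound 1 to compound 3 (beyond the scatter), replaces one side chain with another and already lowers the read-out by a modest amount. Compound 4 `COc1cc(OC)c2c(=O)cc(-c3ccc(-c4ccc(F)nc4)cc3)oc2c1` changes more: 6-fluoropyridin-3-yl in place of 3-(dimethylamino)propoxy on an aromatic carbon. Among the compounds with values here, no measured pair replaces the whole chain with a ring, so the step is poorly anchored; a larger drop is expected, a number 36 percentage points lower from compound 1 to compound 4 (beyond the scatter), because compound 3 gave 70% after a smaller change. Compound 4 is therefore estimated at 50%, within 15% to 85%.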

Compound 4, a percentage reported as inhibition, at one concentration (the size of the read-out at that concentration, not a potency): 19%
For compound 4 the middle estimate is 31 percentage points above the measured one; low and high end bracket the measured number.
By their numbers in this assay, from the lowest: compound 4; then compound 3; then compound 1.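

At this aromatic carbon, 6-fluoropyridin-3-yl in place of an amine-bearing chain gives a large fall, a number 67 percentage points lower from compound 1 to compound 4 (beyond the scatter) and a number 51 percentage points lower from compound 3 to compound 4 (beyond the scatter). Both steps are larger than the modest change between the two chains, so the choice of group here can decide most of the read-out in this assay. No evidence at hand accounts for the fall. Going by these compounds, it remains open whether the loss of the amine or the arrival of the ring matters more. An unsubstituted phenyl ring, or a pyridine ring carrying a dimethylaminopropoxy chain, would bear on this.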